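This account rests on a few compounds, and the source may have more. Where it says the series, first, only, none or still open, it means among the compounds named here.

Within the data shown here, compound 2 `N#Cc1ccc(Cn2cc(COc3ccc(C#N)cc3)nn2)cc1` stands at the higher of the two numbers so far recorded in an assay on isolated protein for inhibition of Aromatase (Homo sapiens), read by fluorescence and colorimetric assay, with a stated time of 30 min (a lower number here means a stronger inhibitor, a higher number a weaker inhibitor), where compound 2 gives 9160 nM. Among the measured compounds shown here, its only neighbour is compound 1 `N#Cc1ccc(Cn2cc(COc3ccccc3)nn2)cc1`, which in this assay gives 6090 nM; the step of a 1.5-fold higher number from compound 1 to compound 2 (0.18 log units; within the scatter) leaves the two within the scatter of each other. Compound 3 `N#Cc1ccc(Cn2cc(COc3ccc(-c4ccccc4)cc3)nn2)cc1` differs from compound 2 by phenyl in place of cyano on an aromatic carbon. For the measured compounds named here, the single measured step that touches that aromatic carbon is a 1.5-fold higher number from compound 1 to compound 2 (0.18 log units; within the scatter), and it shows nothing beyond the scatter; no measured step introduces a phenyl, so the weight of the larger group is untested. Because the step of a 1.5-fold higher number from compound 1 to compound 2 (0.18 log units; within the scatter) was flat, the number for compound 3 is expected to stay near that of compound 2. The expected step in this assay is a 1.5-fold lower number from compound 2 to compound 3 (0.18 log units; within the scatter). The estimate for compound 3 in this assay is 6000 nM, with a range from 1500 nM to 20000 nM.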

Compound 3, half-maximal inhibitory concentration: 11600 nM
For compound 3 the middle estimate is 1.9-fold (0.29 log units) below the measured one; the range from low to high includes it.
By their numbers in this assay, from the lowest: compounds 1, 2 and 3 (each within the scatter of the next).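

In this assay, among these compounds, phenyl, with its six heavy atoms and one six-membered aromatic ring of carbon only, is the first larger group seen on this aromatic carbon para to a large group, and the step of a 1.3-fold higher number from compound 2 to compound 3 (0.10 log units; within the scatter) stays within the scatter. Measured against hydrogen at the same place, the step of a 1.9-fold higher number from compound 1 to compound 3 (0.28 log units; within the scatter) also stays within the scatter, so hydrogen, cyano and phenyl do not separate at this position, even though the entering group is far larger than either of the others. No measured evidence accounts for this flat result.

As far as these compounds go, whether an amine, a carboxylic acid or a longer chain on this aromatic carbon would move the number beyond the scatter remains open. So does whether a change elsewhere in the shared core would do so.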